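Methoxy to methylamino on two alkyl chain lengths

The source may hold more compounds than are shown below. What is called first, only, known or untested is meant among the compounds shown, and "the series" means these compounds.

Measured so far:
compound 1, `CCCCCCCC(CCO)n1cnc2c(OC)ncnc21`, 23900 nM
compound 2, `CCCCCCCC(CCO)n1cnc2c(NC)ncnc21`, 15300 nM
compound 3, `CCCCCCCCCCCC(CCO)n1cnc2c(OC)ncnc21`, 9700 nM

Notes. All three numbers come from a functional assay on SW480 cells (Homo sapiens) for antiproliferative activity, read by MTT assay, with a stated time of 48 h; a higher number here means a weaker inhibitor, a lower number a stronger inhibitor. Compound 2 differs from compound 1 by methylamino in place of methoxy on an aromatic carbon, and that change gave a 1.6-fold lower number from compound 1 to compound 2 (0.19 log units; within the scatter). Compound 3 differs from compound 1 by butyl in place of hydrogen on a saturated chain carbon, eight bonds along the chain from an aromatic nitrogen, which gave a 2.5-fold lower number from compound 1 to compound 3 (0.39 log units; beyond the scatter); compound 3 has the lowest number of the three, though its number and that of compound 2 lie within the scatter of each other.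

Compound 4, `CCCCCCCCCCCC(CCO)n1cnc2c(NC)ncnc21`, has not been measured. It differs from compound 3 by methylamino in place of methoxy on an aromatic carbon, the same change as from compound 1 to compound 2, made here on the longer-chain core. For compound 2 against compound 1 this change was within the scatter, so compound 4 is expected to show a step of a 1.5-fold lower number from compound 3 to compound 4 (0.17 log units; within the scatter) of about the same size, a small move if any. No value for the pair compound 2 against compound 4 exists, so the expectation rests only on a 1.6-fold lower number from compound 1 to compound 2 (0.19 log units; within the scatter).

Compound 4 is estimated at 6500 nM, with a range from 3000 nM to 13000 nM.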

Compound 4, half-maximal inhibitory concentration: 12800 nM
Estimate against measurement, compound 4: 2.0-fold (0.29 log units) below; measured number inside the range.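

Notes on carrying the changes across cores. In this assay, methylamino in place of methoxy on an aromatic carbon gives a 1.3-fold higher number from compound 3 to compound 4 (0.12 log units; within the scatter), so on neither core does this change move the number beyond the scatter, and the two steps agree as far as can be read: the same change on two cores in this assay, a 1.6-fold lower number (0.19 log units; within the scatter) from compound 1 to compound 2 and a 1.3-fold higher number (0.12 log units; within the scatter) from compound 3 to compound 4, 2.1-fold (0.31 log units) apart, within the scatter of two such steps Butyl in place of hydrogen on a saturated chain carbon, eight bonds along the chain from an aromatic nitrogen, gives a 1.2-fold lower number from compound 2 to compound 4 (0.08 log units; within the scatter), which is smaller than the step on the methoxy core, yet the gap between them does not exceed what two such steps allow: the same change on two cores in this assay, a 2.5-fold lower number (0.39 log units; beyond the scatter) from compound 1 to compound 3 and a 1.2-fold lower number (0.08 log units; within the scatter) from compound 2 to compound 4, 2.1-fold (0.31 log units) apart, within the scatter of two such steps These two pairs show no dependence on the core that can be told from scatter, but they do not show that the changes are independent of the core, nor do they give the methylamino change a direction.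

Still open, from the compounds shown here alone, is whether an ethoxy group or a dimethylamino group in place of the methoxy would give a step beyond the scatter on either core. Also open, going by these compounds, is how a longer chain, or a carboxylic acid in place of the terminal hydroxyl, would read in this assay.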